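Working notes: the step from compound 3 to compound 4

This account rests on a few compounds, and the source may have more. Where it says the series, first, only, none or still open, it means among the compounds named here.

In a functional assay on BaF3 cells (Mus musculus) for inhibition, read by MTT assay, with a stated time of 3 days (a higher number here means a weaker inhibitor of growth, a lower number a stronger inhibitor of growth), the measured compounds read as follows, each value a limit:
- compound 1 `O=C(Nc1ccc(Cl)cc1)Nc1ccc(Nc2ncnc3c2OCCN3)cc1` gives > 10000 nM
- compound 2 `Cc1ccc(F)c(NC(=O)Nc2ccc(Nc3ncnc4c3OCCN4)cc2)c1` gives > 10000 nM
- compound 3 `Cc1cc(C)cc(NC(=O)Nc2ccc(Nc3ncnc4c3OCCN4)cc2)c1` gives > 10000 nM

Compound 3 stands at > 10000 nM as a limit and not a number. Among the measured compounds shown here, the series so far shows the limit of > 10000 nM in this assay, at which 3 of the 3 values shown sit, and no ranking of the three follows from it.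

Compound 4 `CC(C)(C)c1cc(NC(=O)Nc2ccc(Nc3ncnc4c3OCCN4)cc2)no1` carries 5-(tert-butyl)-1,2-oxazol-3-yl in place of 3,5-dimethylphenyl on an amide-type nitrogen, counted as 5-(tert-butyl)-1,2-oxazol-3-yl in place of 3,5-dimethylphenyl on an amide-type nitrogen and otherwise unchanged.

For the measured compounds named here, three measured steps bear on this, all swaps at that same place: a step that the two limits leave unreadable from compound 1 to compound 2 and a step that the two limits leave unreadable from compound 1 to compound 3 and a step that the two limits leave unreadable from compound 2 to compound 3 and none of them offers a size to carry over. The incoming group has not been measured in this series, so no direction can be read from these steps.

The step expected here is an at least 1.1-fold lower number from compound 3 to compound 4 (0.04 log units; that floor lies within the scatter) and it remains an estimate. For compound 4 the estimated value is 9000 nM with an expected range from 1500 nM to 20000 nM and a reading that is again only a limit is considered likely.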

Compound 4, concentration for 50% growth inhibition: > 10000 nM
Compound 4 ended at the assay's limit (the forecaster's own chance of this, stated with the estimate: 75%); middle value at least 1.1-fold (0.04 log units) from the limit.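

No step from compound 1, compound 2 or compound 3 to compound 4 can be read, since each value is a limit and not a number: the limit of > 10000 nM in this assay, at which 4 of the 4 values shown sit.

The compounds shown leave open how the groups on the amide-type nitrogen rank in this assay, and whether any of them gives a readable value.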